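This account rests on a few compounds, and the source may have more. Where it says the series, first, only, none or still open, it means among the compounds named here.

Compound 1, with the structure `COc1cc2c(=O)c(C(=O)c3ccc(C)cc3)cn(CC3CC3)c2cc1OC`, was run in an ADME assay on Huh-7 cells (Homo sapiens) for cytotoxicity (on this read-out lower numbers stand for stronger inhibition of growth and higher numbers for weaker inhibition of growth), which gave "not active" (no number reported) for it, so no single number marks where it stands. A second compound, compound 2 with the structure `O=C(OCc1ccc(Cl)cc1)c1cn(Cc2ccc(Cl)cc2)c2cc(N3CCNCC3)c(F)cc2c1=O`, does have a number: in this assay compound 2 gives 1100 nM. Compound 3, with the structure `COc1cc2c(=O)c(C(=O)c3ccc(C)cc3)cn(Cc3ccc(S(C)(=O)=O)cc3)c2cc1OC`, keeps the core of compound 1 and changes one group: 4-(methylsulfonyl)phenyl in place of cyclopropyl on a saturated chain carbon bound to an aromatic nitrogen. Among the measured compounds shown here, no step between two measured compounds shows what such a change does, so the expectation for compound 3 in this assay leans on compound 1 alone and stays weak. Compound 3 is expected to give about 30000 nM, with a likely range from 8000 nM to 100000 nM.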

Compound 3, concentration for 50% growth inhibition: > 50000 nM
Compound 3: only a limit was reported; the forecaster's own chance of this, stated with the estimate: 60%; middle value at least 1.6-fold (0.22 log units) away from the limit.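

In this assay, among the compounds shown here, compound 3 gives > 50000 nM, which is a limit and not a number; compound 1 has no number either, so no step between compound 1 and compound 3 can be read. The compounds shown leave open how far cyclopropylmethyl to 4-(methylsulfonyl)benzyl shifts growth inhibition.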